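Phenyl for cyclohexyl on the sulfonyl sulfur

This account rests on a few compounds, and the source may have more. Where it says the series, first, only, none or still open, it means among the compounds named here.

Compound 3 `O=C(Nc1ccc(S(=O)(=O)C2CCCCC2)cc1)c1ccc([N+](=O)[O-])o1` is known in an ADME assay on IMR-90 cells (Homo sapiens) for cytotoxicity, read by CellTiter-Blue, with a stated time of 46 h (on this read-out higher numbers stand for an effect only at larger amounts of compound and lower numbers for an effect already at smaller amounts), only as a limit. In this assay compound 3 gives > 25000 nM, a limit and not a number. Compound 1 `O=C(Nc1ccc(S(=O)(=O)N2CCC(O)CC2)cc1)c1ccc([N+](=O)[O-])o1` also yields in this assay a limit, > 25000 nM. Compound 2 `N=C1CCN(S(=O)(=O)c2ccc(NC(=O)c3ccc([N+](=O)[O-])o3)cc2)CC1` likewise yields in this assay a limit, > 25000 nM. The steps a step that the two limits leave unreadable from compound 1 to compound 2, a step that the two limits leave unreadable from compound 1 to compound 3 and a step that the two limits leave unreadable from compound 2 to compound 3 cannot be read, since every value sits at the limit of > 25000 nM in this assay, at which 3 of the 3 values shown sit. Compound 4 `O=C(Nc1ccc(S(=O)(=O)c2ccccc2)cc1)c1ccc([N+](=O)[O-])o1` differs from compound 3 by phenyl in place of cyclohexyl on a sulfonyl sulfur. Going by the values given here, no measured step gives a size for a change on this sulfonyl sulfur, so the expected step that the limit leaves unreadable from compound 3 to compound 4 is one that stays within the scatter. Compound 4 is therefore expected to give 30000 nM in this assay, with a range from 15000 nM to 80000 nM.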

Compound 4, half-maximal effective concentration: > 25000 nM
Compound 4 ended at the assay's limit (the forecaster's own chance of this, stated with the estimate: 80%); the middle value is on the limit's open side.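

No step to compound 4 from compound 1, compound 2 or compound 3 can be read, because all four compounds end at the same limit: the limit of > 25000 nM in this assay, at which 4 of the 4 values shown sit.

How far these groups on the sulfonyl sulfur differ in this assay stays open, since the compounds shown give only limits.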